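A Methyl Added to a Difluoromethyl Group

A few compounds are considered here, and "the series" means these few. Any claim that something is new, unique, unknown or untested is made for them only; others in the source may bear on it.

Three diaryl ureas have been measured in an assay on isolated protein for inhibition of serine/threonine-protein kinase TNNI3K (Homo sapiens); on this read-out higher numbers stand for weaker inhibition and lower numbers for stronger inhibition. Compound 1 `CNc1cc(Oc2ccc(NC(=O)Nc3cccc(C(F)F)c3)cc2)ncn1` gives 100 nM, which places it as the second highest of the three numbers. Its nearest neighbour is compound 3 `CNc1cc(Oc2ccc(NC(=O)Nc3cccc(C(F)(F)F)c3)cc2Cl)ncn1`, which carries a trifluoromethyl group and a chlorine on the shared core and gives 50 nM, a gap that falls within the usual scatter, so the two cannot be told apart. The furthest is compound 2 `COc1cc(Oc2ccc(NC(=O)Nc3cccc(C(F)(F)F)c3)cc2)ncn1`, where a methoxy group replaces the methylamino group on the core; it gives 4000 nM, a difference that lies well beyond the scatter.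

The next compound, compound 4 `CNc1cc(Oc2ccc(NC(=O)Nc3cccc(C(C)(F)F)c3)cc2)ncn1`, differs from compound 1 in one place: methyl in place of hydrogen on a saturated chain carbon bound to an aromatic carbon and two fluorine atoms. Among the compounds with values here, no two measured compounds differ by exactly this change, so nothing among the measured values sets a direct precedent. Since the difluoromethyl to trifluoromethyl difference between compound 1 and compound 3 is accompanied by a gap within the scatter, a small change at the same carbon is expected to behave similarly. The step of a 1.2-fold higher number from compound 1 to compound 4 (0.08 log units; within the scatter) is therefore expected to be small, with no direction beyond the scatter. In this assay compound 4 is estimated at 120 nM, likely between 40 nM and 400 nM.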

Compound 4, half-maximal inhibitory concentration: 40 nM
Compound 4: the middle estimate sits 3.0-fold (0.48 log units) above what was measured; measured number inside the range.
By their numbers in this assay, from the lowest: compounds 4, 3 and 1 (each within the scatter of the next, the first and the last beyond it); then compound 2.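

In this assay, within the data shown here, the swap from difluoromethyl to 1,1-difluoroethyl gives the first step in this set that changes one place only (a 2.5-fold lower number from compound 1 to compound 4 (0.40 log units; beyond the scatter)). It shows that this saturated chain carbon, bound to an aromatic carbon and two fluorine atoms, accepts a methyl in place of its hydrogen with no loss of inhibition, and that the number instead moves modestly downward, beyond the usual scatter. Nothing measured on these compounds accounts for this gain.

The compounds shown compare only hydrogen and methyl on this carbon, so they leave open whether an ethyl group or a hydroxyl group there would lower the number further or reverse the gain. They also leave open whether the same step would hold on a core carrying the chlorine of compound 3 or the methoxy group of compound 2, since the 1,1-difluoroethyl group appears here only in compound 4.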